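Diamino-Substituted Fused Core: Aryl Ether to Aryl Thioether

The compounds below may be only part of what the source reports. "The series", "measured", "known", "first", "only" and "open" are said of these compounds alone.

Measured compounds:
- compound 1 `Nc1cc(N)c2nc(-c3ccccc3)c(Oc3ccc(Cl)c(Cl)c3)nc2c1`: 18200 nM
- compound 2 `COc1ccc(CNc2nc3cc(N)cc(N)c3nc2-c2ccccc2)cc1OC`: 24000 nM

In a functional assay on NCI-H460 cells (Homo sapiens) for inhibition, read by sulforhodamine B assay, with a stated time of 48 h (on this read-out higher numbers stand for weaker inhibition of growth and lower numbers for stronger inhibition of growth), compound 1 gives 18200 nM, the lowest of the two numbers recorded. In this assay compound 2 gives 24000 nM; the gap between compound 2 and compound 1 lies within the scatter, so the two values show no order between them. Compound 2 differs from compound 1 at more than one place, so no single step can be read from the pair.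

Compound 3 `Nc1cc(N)c2nc(-c3ccccc3)c(Sc3ccc(F)cc3)nc2c1` is not yet measured in this assay. It differs from compound 1 by (4-fluorophenyl)sulfanyl in place of 3,4-dichlorophenoxy on an aromatic carbon. Among the compounds with values here, no step between measured compounds covers this kind of exchange, so the direction of the step from compound 1 to compound 3 cannot be read from what has been measured. The working expectation is no step beyond the scatter: a 1.1-fold higher number from compound 1 to compound 3 (0.04 log units; within the scatter) is the estimated change. On that basis compound 3 is expected to give about 20000 nM in this assay, with a range from 8000 nM to 50000 nM.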

Compound 3, concentration for 50% growth inhibition: 21900 nM
For compound 3 the middle estimate is 1.1-fold (0.04 log units) below the measured one, within the range that was stated.
By their numbers in this assay, from the lowest: compounds 1, 3 and 2 (each within the scatter of the next).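

In this assay, within the data shown here, placing (4-fluorophenyl)sulfanyl instead of 3,4-dichlorophenoxy on the aromatic carbon next to the ring nitrogen gives a 1.2-fold higher number from compound 1 to compound 3 (0.08 log units; within the scatter), the first single-place step at this position, which the pair of compound 1 and compound 2 could not supply. This exchange alters the linking atom, from oxygen to sulfur, and the halogen substitution on the aryl ring at once, so the step describes the whole group swap and assigns no separate contribution to either part. No measured property of either group is available to bear on this result.

As far as these compounds go, whether the linking atom and the halogen pattern each leave the number unchanged, or whether their contributions merely offset each other, stays open, and a (3,4-dichlorophenyl)sulfanyl group on the same carbon would separate the two. From the compounds shown here alone, it also remains open whether a group of a different kind at this position, such as a morpholine ring or an aryl ring bearing a carboxylic acid, would move the number beyond the scatter.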